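The compounds below may be only part of what the source reports. "The series", "measured", "known", "first", "only" and "open" are said of these compounds alone.

Three compounds of the series have numbers in a functional assay on LoVo cells (Homo sapiens) for cytotoxicity, read by MTT assay, with a stated time of 72 h; on this read-out lower numbers stand for stronger inhibition and higher numbers for weaker inhibition. Compound 1 `O=C(Nc1ccc(-n2ncc3c(Cl)cccc32)cc1)Nc1ccc(Cl)c(C(F)(F)F)c1` gives 3600 nM. Compound 2 `O=C(Nc1ccc(-n2ncc3c(C(F)(F)F)cccc32)cc1)Nc1ccc(C(F)(F)F)cc1` gives 2200 nM, and compound 3 `O=C(Nc1ccc(-n2ncc3c(Cl)cccc32)cc1)Nc1ccc(C(F)(F)F)cc1` gives 5100 nM. Compound 1 stands second highest of the three, but its gap to compound 3 and its gap to compound 2 both lie within the scatter, so no order among the three can be read from these numbers. Among the compounds with values here, the only single-point step measured so far is a 2.3-fold higher number from compound 2 to compound 3 (0.37 log units; beyond the scatter), a modest move.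

Compound 4 `O=C(Nc1ccc(-n2ncc3cccnc32)cc1)Nc1ccc(Cl)c(C(F)(F)F)c1` is not yet measured. Relative to compound 1 the change is a group of 9 heavy atoms (6 carbon, 3 nitrogen; one five-membered aromatic ring with 2 hetero atoms, one six-membered aromatic ring with 1 hetero atom) in place of a group of 10 heavy atoms (7 carbon, 2 nitrogen, 1 chlorine; one five-membered aromatic ring with 2 hetero atoms, one six-membered aromatic ring of carbon only), on an aromatic carbon. Within the data shown here, no measured step in this assay touches this part of the molecule: the step from compound 2 to compound 3 alters a substituent on the group that compound 4 loses but keeps that group itself, and compound 1 and compound 3 differ elsewhere, by a chloro, with values within the scatter of each other. With nothing in the series speaking for a move in either direction, the expected step for compound 4 is a 1.3-fold higher number from compound 1 to compound 4 (0.10 log units; within the scatter) in this assay, inside the scatter, with a wide range to reflect the untested change. Compound 4 is estimated at 4500 nM, between 1500 nM and 14000 nM.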

Compound 4, half-maximal inhibitory concentration: 32000 nM
Estimate against measurement, compound 4: 7.1-fold (0.85 log units) below; the measured number lies above the stated range.
By their numbers in this assay, from the lowest: compounds 2, 1 and 3 (each within the scatter of the next, the first and the last beyond it); then compound 4.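

In this assay, within the data shown here, replacing the 4-chloro-1H-indazol-1-yl group of compound 1 gives an 8.9-fold higher number from compound 1 to compound 4 (0.95 log units; beyond the scatter), the first measured step that alters this group as a whole and not just a substituent on it. This step is larger than a 2.3-fold higher number from compound 2 to compound 3 (0.37 log units; beyond the scatter), which only exchanges trifluoromethyl for chloro on the same group, so in these compounds the number responds more to the change of the whole group than to that substituent exchange. The step joins two changes in one move, the loss of the chloro and the entry of a nitrogen into the six-membered ring, and nothing at hand gives a cause for it.

Which of these two changes carries the step remains open, as the compounds shown do not separate them. A nitrogen-containing six-membered ring that keeps a chloro, or a carbon-only ring with an amine or a methoxy group in place of the chloro, would show whether the ring nitrogen or the substituent matters more.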